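The compounds below may be only part of what the source reports. "The series", "measured", "known", "first", "only" and "open" are said of these compounds alone.

Working notes on the series. For the measured compounds named here, in an assay on isolated protein for inhibition of Aromatase (Homo sapiens), read by fluorescence, using NADPH, with a stated time of 30 min, tested at 50 uM (a lower number here means less inhibition, a higher number more inhibition at the concentration tested (going by the name of the read-out)), three compounds have numbers so far. Compound 2, `c1cncc(-c2cc3ccccc3[nH]2)c1`, gives 81.6%. Compound 1, `Nc1ccc2[nH]c(-c3ccccc3)cc2c1`, gives 41.4%, the second highest of the three. Compound 3, `CC(C)(C)OC(=O)n1c(-c2ccccc2)cc2ccccc21`, gives 11.9%. Compound 1 thus sits apart from both neighbours beyond the scatter: nearest to compound 3, whose number is lower, and furthest from compound 2, whose number is higher. Going by the values given here, no two of these three compounds differ in one place only, so no single-point step is known within the measured set.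

Compound 4, `N#Cc1ccc2[nH]c(-c3ccccc3)cc2c1`, is not yet measured. It differs from compound 1 as follows: cyano in place of amino on an aromatic carbon. The exchange sits on an aromatic carbon of the six-membered aromatic ring of carbon only, part of the fused system of two rings. Nothing measured in this assay bears on an amino-to-cyano exchange, so the direction of the step is open. In this assay the expected step is a number 3.6 percentage points higher from compound 1 to compound 4 (within the scatter), of modest size and possibly within the scatter. For compound 4 the estimate is 45%, with a range from 25% to 65%.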

Compound 4, a percentage reported as inhibition, at one concentration (the size of the read-out at that concentration, not a potency): 82.3%
Beside the measured number, compound 4's estimate is 37.3 percentage points below it; the whole stated range lies below it.
By their numbers in this assay, from the lowest: compound 3; then compound 1; then compounds 2 and 4 (each within the scatter of the next).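

In this assay, this place on the six-membered aromatic ring of carbon only, part of the fused system, proves sensitive to what it carries: cyano in place of amino gives a number 40.9 percentage points higher from compound 1 to compound 4 (beyond the scatter) with the rest of the structure unchanged. For the compounds shown here, the exchange removes a hydrogen-bond donor, keeps a hydrogen-bond acceptor and adds a heavy atom and a triple bond, and these differences arrive together, so the single step cannot separate them. No measurement on hand accounts for the size of the step.

As far as these compounds go, whether the step reflects the arrival of cyano, the departure of amino or both remains open. A plain hydrogen, a chlorine or a methoxy group at this place would help to separate those readings.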